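The compounds below may be only part of what the source reports. "The series", "measured", "known", "first", "only" and "open" are said of these compounds alone.

Measured compounds:
- compound 1 `OC[C@H]1O[C@@H](n2cnc3c(NCc4cccc(F)c4)ncnc32)[C@H](O)[C@@H]1O` — 7600 nM
- compound 2 `OC[C@H]1O[C@@H](n2cnc3c(NCc4ccc(Cl)cc4Cl)ncnc32)[C@H](O)[C@@H]1O` — 106000 nM
- compound 3 `COc1ccc(CNc2ncnc3c2ncn3C2OC(CO)[C@@H](O)[C@H]2O)c(O)c1` — 80800 nM

For the measured compounds named here, in a functional assay on K562 cells (Homo sapiens) for antiproliferative activity, with a stated time of 72 h (a lower number here means a stronger inhibitor, a higher number a weaker inhibitor), compound 2 gives the highest number of the three; compound 3 sits within the scatter of it, while compound 1 is separated from it by a 14-fold higher number from compound 1 to compound 2 (1.14 log units; beyond the scatter), the only step in the set that changes the same place. Compound 4 `Cc1cccc(CNc2ncnc3c2ncn3[C@@H]2O[C@H](CO)[C@@H](O)[C@H]2O)c1O` differs from compound 2 by 2-hydroxy-3-methylphenyl in place of 2,4-dichlorophenyl on a saturated chain carbon bound to a nitrogen on an aromatic ring. Going by the values given here, the one step that bears on this place is large, so the ring here clearly matters, but no step connects a 2-hydroxy-bearing ring to any other; compound 3, which carries such a ring, shows a number close to compound 2. For compound 4 the step is therefore expected to be modest, a 1.8-fold lower number from compound 2 to compound 4 (0.25 log units; within the scatter), with the estimate 60000 nM in a range from 15000 nM to 200000 nM.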

Compound 4, half-maximal inhibitory concentration: 18000 nM
Compound 4: the middle estimate sits 3.3-fold (0.52 log units) above what was measured; the measured number falls inside the stated range.
By their numbers in this assay, from the lowest: compound 1; then compound 4; then compounds 3 and 2 (each within the scatter of the next).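

In this assay the position tolerates the 2-hydroxy-3-methylphenyl ring far better than the 2,4-dichlorophenyl ring, shown by a 5.9-fold lower number from compound 2 to compound 4 (0.77 log units; beyond the scatter) in this series, but the ring does not match the 3-fluorophenyl ring, shown by a 2.4-fold higher number from compound 1 to compound 4 (0.37 log units; beyond the scatter) here. The three rings on compounds 1, 2 and 4 therefore give three separate levels, each step beyond the scatter. No measurement shown explains this order.

Still open, from the compounds shown here alone, is whether the hydroxyl or the methyl accounts for the step, and how a ring bearing an aminomethyl group or a carboxylic acid would compare at this place.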